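Swapping the amide on the piperazine for a benzyl

This account rests on a few compounds, and the source may have more. Where it says the series, first, only, none or still open, it means among the compounds named here.

In a functional assay on HEK293 cells for agonist activity at transient receptor potential cation channel subfamily A member 1 (Homo sapiens), read by fluorescence and calcium flux, with stated times of 1 s and 60 s (a higher number here means that more compound is needed for the effect, a lower number that less compound is needed), compound 3 `O=C(NCc1ccccc1)c1cnc(N2CCN(C(=O)c3c(F)cccc3F)CC2)nc1NC1CC1` gives 27 nM. This is the lowest of the two numbers recorded here. Its nearest neighbour is compound 1 `CC(C)CNc1nc(N2CCN(Cc3ccccc3)CC2)ncc1C(=O)NCc1ccccc1`, which already carries a benzyl on the ring nitrogen but a different amine on the shared core; in this assay compound 1 gives 79 nM, a number higher than that of compound 3 by more than the usual scatter. Compound 2 `O=C(NCc1ccccc1)c1cnc(N2CCN(C(=O)c3ccccc3)CC2)nc1NC1CC1` lacks the fluorines of compound 3, and in this assay compound 2 is recorded as "not active" (no number reported), with no number attached.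

Compound 4 `O=C(NCc1ccccc1)c1cnc(N2CCN(Cc3ccccc3)CC2)nc1NC1CC1` is the next step: benzyl in place of (2,6-difluorophenyl)carbonyl on an amine nitrogen in a ring. Going by the values given here, no measured pair shows this exact exchange, so the expectation rests on compound 1, where the same benzyl on the same ring nitrogen gives 79 nM alongside a different amine, showing that the benzyl is compatible with activity. The expected step in this assay is a 2.2-fold higher number from compound 3 to compound 4 (0.35 log units; beyond the scatter), a modest rise that sits close to the edge of the scatter. Compound 4 is therefore estimated at 60 nM in this assay, with a likely range from 15 nM to 300 nM.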

Compound 4, half-maximal effective concentration: "not active" (no number reported)
Compound 4: no number reported; there is nothing to compare the estimate with.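

Compound 4, like compound 2, is recorded in this assay as "not active" with no number, so no step can be read from compound 3 to compound 4. Nothing shown here offers a reason for this result. The compounds leave open whether the different amine on the shared core matters, since compound 1 gives 79 nM with the same benzyl.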